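The source may hold more compounds than are shown below. What is called first, only, known or untested is meant among the compounds shown, and "the series" means these compounds.

Within the data shown here, in a functional assay on Gurav cells (Homo sapiens) for inhibition, read by sulforhodamine B assay (on this read-out higher numbers stand for weaker inhibition of growth and lower numbers for stronger inhibition of growth), compound 1 `FC(F)(F)c1ccc(-c2ccc(-c3ccc(-c4nc5ccccc5[nH]4)cc3)cc2)cc1` gives 39100 nM, the lower of the two numbers so far, and compound 2 `FC(F)(F)Oc1ccc(-c2ccc(-c3ccc(-c4nc5ccccc5[nH]4)cc3)cc2)cc1` gives 100000 nM. Compound 3 `Clc1cccc(-c2ccc(-c3ccc(-c4nc5ccccc5[nH]4)cc3)cc2)c1` carries 3-chlorophenyl in place of the 4-(trifluoromethyl)phenyl of compound 1 (3-chlorophenyl in place of 4-(trifluoromethyl)phenyl on an aromatic carbon). Among the measured compounds shown here, only one measured step bears on this change, and only indirectly: a 2.6-fold higher number from compound 1 to compound 2 (0.41 log units; beyond the scatter) is modest and swaps trifluoromethoxy for trifluoromethyl. For the measured compounds named here, no measured compound carries 3-chlorophenyl, so no step beyond the scatter is expected in this assay. The expected step is a 1.3-fold higher number from compound 1 to compound 3 (0.11 log units; within the scatter). The estimate for compound 3 is 50000 nM, with an expected range of 15000 nM to 120000 nM.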

Compound 3, concentration for 50% growth inhibition: 2190 nM
Compound 3: the middle estimate sits 23-fold (1.36 log units) above what was measured; measured number outside the range, below it.
By their numbers in this assay, from the lowest: compound 3; then compound 1; then compound 2.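

In this assay, among these compounds, this position proved far more sensitive than the earlier compounds showed: an 18-fold lower number from compound 1 to compound 3 (1.25 log units; beyond the scatter), a large step where the trifluoromethoxy swap gave only a modest one. Compound 3 is thus the strongest growth inhibitor of the three, and its 3-chlorophenyl clearly outperforms the 4-(trifluoromethyl)phenyl of compound 1. No measurement available here explains this gain.

The change replaces both the substituent and its place on the phenyl, and these compounds do not separate the two. As far as these compounds go, whether a methoxy group, an amine or a carboxylic acid here would keep the gain remains open.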